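A few compounds are considered here, and "the series" means these few. Any claim that something is new, unique, unknown or untested is made for them only; others in the source may bear on it.

Within the data shown here, in a physicochemical assay for lipophilicity, using the shake flask method, at pH 7.4 (a lower number here means a more polar compound, a higher number a more lipophilic compound), compound 2 (`CC(C)(C)c1cccc(OCC(=O)Nc2ccc(OCC(=O)O)c(F)c2)c1`) gives 0.35, the higher of the two numbers so far. Compound 1 (`CC(Oc1ccccc1)C(=O)Nc1ccc(OCC(=O)O)c(F)c1`) gives -0.18, lower by more than the usual scatter. Compound 3 (`CC(Oc1cccc(C(C)(C)C)c1)C(=O)Nc1ccc(OCC(=O)O)c(F)c1`) comes from compound 2 through a single change: methyl in place of hydrogen on a saturated chain carbon bound to a carbonyl carbon and an oxygen on an aromatic ring. Among the measured compounds shown here, no measured pair shows this change alone. In this assay, a small rise close to the usual scatter is expected, estimated as a number 0.30 log units higher from compound 2 to compound 3 (within the scatter). For compound 3 the estimated value is 0.65, with an expected range from 0.3 to 1.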

Compound 3, distribution coefficient: 0.63
For compound 3 the middle estimate is 0.02 log units above the measured one; measured number inside the range.
By their numbers in this assay, from the lowest: compound 1; then compounds 2 and 3 (each within the scatter of the next).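

The chain carbon bound to a carbonyl carbon and an oxygen on an aromatic ring now has its first single-change reading: methyl in place of hydrogen there gives a number 0.28 log units higher from compound 2 to compound 3 (within the scatter) in this assay, so this step cannot be told from repeat-measurement noise. The second single change, tert-butyl in place of hydrogen on an aromatic carbon, gives a number 0.81 log units higher from compound 1 to compound 3 (beyond the scatter), a step that stands clear of the scatter. Nothing measured here gives a reason for either step.

On these data alone, how an ethyl group or an amine on that same chain carbon would read in this assay remains open.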